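Phenoxy substituent change in the guanidine-bearing series

The compounds below may be only part of what the source reports. "The series", "measured", "known", "first", "only" and "open" are said of these compounds alone.

Of the compounds shown here, three on a shared core have been measured: compound 1 `CN(Cc1ccc(OCCCNC(=N)N)cc1)c1nc2ccc(Oc3ccc(C(F)(F)F)cc3)cc2s1`, compound 2 `CN(Cc1ccc(OCCCNC(=N)N)cc1)c1nc2ccc(Oc3ccc(F)cc3)cc2s1` and compound 3 `N=C(N)NCCCOc1ccc(CNc2nc3ccc(Oc4ccc(F)cc4)cc3s2)cc1`. In an assay on cells for inhibition of Voltage-dependent T-type calcium channel subunit alpha-1H (Homo sapiens), read by FLIPR and calcium flux, with stated times of 600 s and 300 s (a higher number here means a weaker inhibitor, a lower number a stronger inhibitor), compound 2 gives 521000 nM, the highest number of the three. Compound 1 gives 212000 nM in this assay, and the step of a 2.5-fold higher number from compound 1 to compound 2 (0.39 log units; beyond the scatter) is the only one in the set that touches the substituent on the phenoxy ring. Compound 3 gives 288000 nM, and the step of a 1.8-fold lower number from compound 2 to compound 3 (0.26 log units; within the scatter) concerns the ring nitrogen instead and does not bear on the present change.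

Compound 4 `CN(Cc1ccc(OCCCNC(=N)N)cc1)c1nc2ccc(Oc3ccc(C#N)cc3)cc2s1` differs from compound 2 by cyano in place of fluoro on an aromatic carbon. For the measured compounds named here, no measured compound carries a cyano group, so the single relevant step, modest in size, gives only a loose anchor. The step of a 1.3-fold lower number from compound 2 to compound 4 (0.11 log units; within the scatter) is therefore expected to stay modest, with no firm direction. For compound 4 the estimate in this assay is 400000 nM, with a range from 150000 nM to 1000000 nM.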

Compound 4, half-maximal inhibitory concentration: 153000 nM
Estimate against measurement, compound 4: 2.6-fold (0.42 log units) above; the measured number falls inside the stated range.
By their numbers in this assay, from the lowest: compounds 4, 1, 3 and 2 (each within the scatter of the next, the first and the last beyond it).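

In this assay, the phenoxy substituent now has a second replacement for fluoro that separates from compound 2, with a 3.4-fold lower number from compound 2 to compound 4 (0.53 log units; beyond the scatter), so the lower number seen with trifluoromethyl in compound 1 is not unique to that group among the three compounds compared here. Cyano and trifluoromethyl cannot be told apart at this position, since a 1.4-fold lower number from compound 1 to compound 4 (0.14 log units; within the scatter) lies within the scatter. Nothing available accounts for fluoro standing apart from these two groups.

Going by these compounds, whether chloro, methoxy or an unsubstituted phenoxy ring would group with fluoro or with cyano and trifluoromethyl remains open. Also open, on these data alone, is whether the step from 4-fluorophenoxy to 4-cyanophenoxy holds on the hydrogen-bearing nitrogen of compound 3.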